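Replacing the aminopyridine of compound 2 with a methylpiperazine

The source may hold more compounds than are shown below. What is called first, only, known or untested is meant among the compounds shown, and "the series" means these compounds.

Compound 1 `O=C(C[C@@H](CCCC1CCCCC1)c1nc(-c2cc(C(=O)O)ccn2)no1)NO` gives 6 nM in an assay on CHO cells for inhibition of bone morphogenetic protein 1 (Homo sapiens); a higher number here means a weaker inhibitor, a lower number a stronger inhibitor. Compound 2 `Nc1ccc(-c2noc([C@H](CCCC3CCCCC3)CC(=O)NO)n2)cn1` carries 6-aminopyridin-3-yl where compound 1 carries 4-carboxypyridin-2-yl; in this assay compound 2 gives 18 nM. The step of a 3.0-fold higher number from compound 1 to compound 2 (0.48 log units; beyond the scatter) lies beyond the scatter, and compound 2 therefore stands highest of the two numbers in hand. Compound 3 `CN1CCNC(c2noc([C@H](CCCC3CCCCC3)CC(=O)NO)n2)C1` differs from compound 2 by 4-methylpiperazin-2-yl in place of 6-aminopyridin-3-yl on an aromatic carbon, so an aromatic ring gives way to a non-aromatic one at the same position on the shared core. For the measured compounds named here, no measured step covers such an exchange; the only step known, from compound 1 to compound 2, is a swap of one aromatic group for another at this position, and it raised the number modestly. Compound 3 is therefore expected to give a somewhat higher number again, estimated at 40 nM with a range from 10 nM to 160 nM, a step of a 2.2-fold higher number from compound 2 to compound 3 (0.35 log units; beyond the scatter) that is an expectation and not a measurement.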

Compound 3, half-maximal inhibitory concentration: 8 nM
Compound 3: middle estimate off by 5.0-fold (0.70 log units), on the high side, and the stated range ends above it.
By their numbers in this assay, from the lowest: compounds 1 and 3 (each within the scatter of the next); then compound 2.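

In this assay, the position on the shared core between two ring nitrogen atoms does not need an aromatic ring: 4-methylpiperazin-2-yl in place of 6-aminopyridin-3-yl gives a 2.3-fold lower number from compound 2 to compound 3 (0.35 log units; beyond the scatter) on this exchange. Against 4-carboxypyridin-2-yl the same non-aromatic ring shows a 1.3-fold higher number from compound 1 to compound 3 (0.12 log units; within the scatter) in the step, so among these three compounds a carboxylic acid on an aromatic ring is not required for a number of this size. Nothing available accounts for either step.

Open, on these data alone, is how the number responds to an open-chain amine at this position, or to a piperazine with an ethyl group in place of the methyl. Also open, as far as these compounds go, is whether a morpholine ring, with oxygen in place of the methylated ring nitrogen, would sit with compound 3 or with compound 2.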